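This account rests on a few compounds, and the source may have more. Where it says the series, first, only, none or still open, it means among the compounds named here.

Measured compounds:
compound 1 `CCc1ccc(-n2nc(-c3ccc(C(F)(F)F)cc3O)nc2-c2ccccc2O)cc1` — 64.4%
compound 2 `CC(C)c1ccc(-n2nc(-c3ccc(C(F)(F)F)cc3O)nc2-c2ccccc2O)cc1` — 69.7%
compound 3 `COc1ccc(-n2nc(-c3ccc(C(F)(F)F)cc3O)nc2-c2ccccc2O)cc1` — 69%

In a functional assay on PC-12 cells (Rattus norvegicus) for cytotoxicity, read by MTT assay, with stated times of 2 h and 24 h, tested at 1 uM (on this read-out higher numbers stand for a stronger effect at the one concentration tested and lower numbers for a weaker effect), the three measured compounds sit close together. Compound 2 holds the highest of the three numbers, but the separations to its neighbours are within the scatter: a number 0.7 percentage points lower from compound 2 to compound 3 (within the scatter) and, seen from the other side, a number 5.3 percentage points higher from compound 1 to compound 2 (within the scatter). The three differ only in the substituent on the aryl ring attached to the aromatic nitrogen of the shared core, and none of the exchanges there has moved the read-out beyond the scatter, including a number 4.6 percentage points higher from compound 1 to compound 3 (within the scatter).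

Compound 4 `Cc1cc(C)cc(-n2nc(-c3ccc(C(F)(F)F)cc3O)nc2-c2ccccc2O)c1` is the next member of this same variation. Its difference from compound 2 is 3,5-dimethylphenyl in place of 4-isopropylphenyl on an aromatic nitrogen. Within the data shown here, the steps that bear on this exchange are the three already made on the same aryl group, all within the scatter, so the expectation for this assay is a step of no real size in either direction. Compound 4 is therefore expected to come out at 67%, with a range from 57% to 77%, which corresponds to an estimated step of a number 2.7 percentage points lower from compound 2 to compound 4 (within the scatter).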

Compound 4, a percentage reported as activity, at one concentration (the size of the read-out at that concentration, not a potency): 76.9%
The estimate for compound 4 lay 9.9 percentage points below the measured number, and the stated range covers the measured number.
By their numbers in this assay, from the lowest: compounds 1, 3, 2 and 4 (each within the scatter of the next, the first and the last beyond it).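

In this assay, among these compounds, the exchange at the aromatic nitrogen gives the first step in this variation that lies beyond the scatter, a modest one: a number 12.5 percentage points higher from compound 1 to compound 4 (beyond the scatter), with 3,5-dimethylphenyl in place of 4-ethylphenyl. The same group does not separate from the other two aryl groups, since a number 7.2 percentage points higher from compound 2 to compound 4 (within the scatter) and a number 7.9 percentage points higher from compound 3 to compound 4 (within the scatter) are both within the scatter, so the position tolerates all four groups with only the two ends of the set, compound 1 and compound 4, lying apart. No measurement on hand accounts for the step from the ethyl-bearing aryl group to the dimethyl-bearing one.

The compounds shown cannot tell whether that step follows from the presence of two methyl groups on the ring or from where they sit, as no 3-methylphenyl, 4-methylphenyl or 3,5-dimethoxyphenyl group stands among them for comparison. Going by these compounds, the aryl groups here carry only short alkyl chains or methoxy, so how this read-out responds to an amine or a carboxylic acid on that ring remains open, as does any change at the trifluoromethyl group or the two phenol hydroxyls of the shared core.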